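Carboxy in Place of Trifluoromethyl: Expecting Compound 4

This account rests on a few compounds, and the source may have more. Where it says the series, first, only, none or still open, it means among the compounds named here.

compound 1 `Cc1n[nH]c(C(=O)O)c1Cc1ccc(C(F)(F)F)cc1`: 12%
compound 2 `Cc1n[nH]c(C(=O)O)c1Cc1cccc(C(F)(F)F)c1`: 23%
compound 3 `Cc1n[nH]c(C(=O)O)c1Cc1ccc(C(=O)O)cc1`: 22%

These three compounds were tested in an assay on isolated protein for inhibition of 2-Hydroxyacid oxidase 2 (Homo sapiens), tested at 10 uM; on this read-out higher numbers stand for a stronger effect at the one concentration tested and lower numbers for a weaker effect. Compound 1 and compound 2 contain the same atoms joined differently; the difference between the two cores is not broken down here. From compound 1 to compound 3 the change is carboxy in place of trifluoromethyl on an aromatic carbon, and the result was a number 10 percentage points higher from compound 1 to compound 3 (within the scatter). Compound 2 shows the highest of the three numbers, yet its gap to compound 3 lies within the scatter; only its gap to compound 1 lies beyond it.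

Compound 4 `Cc1n[nH]c(C(=O)O)c1Cc1cccc(C(=O)O)c1` has not been measured. It differs from compound 2 by carboxy in place of trifluoromethyl on an aromatic carbon, the same kind of change as before, now meta to a large group rather than para to a large group. Because the earlier step was a number 10 percentage points higher from compound 1 to compound 3 (within the scatter) and stayed within the scatter, a similarly modest step is expected: a number 7 percentage points higher from compound 2 to compound 4 (within the scatter). Compound 4 is therefore estimated at 30%, plausibly between 12% and 50%.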

Compound 4, a percentage reported as inhibition, at one concentration (the size of the read-out at that concentration, not a potency): 0%
Compound 4: the middle estimate sits 30 percentage points above what was measured; the whole stated range lies above it.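

Putting carboxy in place of trifluoromethyl gave a number 23 percentage points lower from compound 2 to compound 4 (beyond the scatter), so the earlier step on the other core offers no safe guide to this one. The two steps do not match in this assay: the same change on two cores in this assay, a number 10 percentage points higher (within the scatter) from compound 1 to compound 3 and a number 23 percentage points lower (beyond the scatter) from compound 2 to compound 4, 33 percentage points apart, beyond the scatter of two such steps. This rests on a single pair of steps read at one concentration, and it shows neither why they part nor how the change would behave on any further core.

The compounds shown leave open whether an amine or a nitrile on that aromatic carbon would give a number closer to that of the trifluoromethyl compound or to that of the carboxy compound. They also leave open what an amide in place of carboxy would do on each core.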